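Dimethoxyphenyl Variant of Two Glucosides

The source may hold more compounds than are shown below. What is called first, only, known or untested is meant among the compounds shown, and "the series" means these compounds.

Within the data shown here, only two compounds have been measured in an assay for inhibition of glucose-6-phosphatase catalytic subunit 1 (Rattus norvegicus), tested at 100 uM; a higher number here means more inhibition at the concentration tested (going by the name of the read-out), a lower number less inhibition. Compound 2 `CCOC(=O)C(C(=O)OCC)C(CC(=O)C[C@@H]1O[C@H](CO)[C@@H](O)[C@H](O)[C@H]1O)c1ccccc1` gives -3.3%, and compound 1 `CCOC(=O)C(C(=O)OCC)C(CC(=O)C[C@@H]1O[C@H](CO)[C@@H](O)[C@H](O)[C@H]1O)c1ccc(Cl)cc1` gives -6%; the step of a number 2.7 percentage points higher from compound 1 to compound 2 (within the scatter) is within the scatter, so the two stand together near zero. Compound 3 `CCOC(=O)C(C(=O)OCC)C(CC(=O)C[C@@H]1O[C@H](CO)[C@@H](O)[C@H](O)[C@H]1O)c1ccc(OC)c(OC)c1` differs from compound 2 by 3,4-dimethoxyphenyl in place of phenyl on a saturated chain carbon bound to two saturated chain carbons. Among the measured compounds shown here, the only measured step that bears on this altered the aromatic ring and produced no change beyond the scatter. Compound 3 is therefore expected to show a number 1.3 percentage points higher from compound 2 to compound 3 (within the scatter), nothing beyond the scatter. The estimate for compound 3 is -2%, ranging from -15% to 12%.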

Compound 3, a percentage reported as inhibition, at one concentration (the size of the read-out at that concentration, not a potency): 36.2%
Estimate against measurement, compound 3: 38.2 percentage points below; measured number outside the range, above it.
By their numbers in this assay, from the lowest: compounds 1 and 2 (each within the scatter of the next); then compound 3.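

In this assay, 3,4-dimethoxyphenyl in place of phenyl on this saturated chain carbon gives a number 39.5 percentage points higher from compound 2 to compound 3 (beyond the scatter) and, in place of 4-chlorophenyl, gives a number 42.2 percentage points higher from compound 1 to compound 3 (beyond the scatter) while the earlier exchange of chloro for hydrogen stayed within the scatter. The read-out at this position therefore does respond to the aromatic group, which the first two compounds could not show. Nothing measured here explains the rise.

From the compounds shown here alone, it remains open whether both methoxy groups are needed, or whether 4-methoxyphenyl alone, or a ring carrying an amine, would give a similar number.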